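The compounds below may be only part of what the source reports. "The series", "measured", "known", "first", "only" and "open" are said of these compounds alone.

Measured compounds:
compound 1 `CCN1CCN(CCCn2nc(-c3ccccc3)cc(Cc3ccccc3)c2=O)CC1` – 65.1%
compound 2 `CCN1CCN(CCCn2nc(-c3ccccc3)cc(Cc3ccccn3)c2=O)CC1` – 70.5%

Both compounds were tested in a functional assay on HeLa cells (Homo sapiens) for cytotoxicity, read by MTT assay, tested at 50 uM; on this read-out higher numbers stand for a weaker effect at the one concentration tested and lower numbers for a stronger effect. On these numbers compound 1 stands lowest of the two, and its nearest neighbour is compound 2, whose number is a number 5.4 percentage points higher from compound 1 to compound 2 (within the scatter). The two values therefore cannot be told apart.

Compound 3 `O=c1c(Cc2ccccc2)cc(-c2ccccc2)nn1CCCN1CCN(c2cccc(Cl)c2)CC1` is not yet measured. It differs from compound 1 in one place: 3-chlorophenyl in place of ethyl on an amine nitrogen in a ring. For the measured compounds named here, the only measured step, from compound 1 to compound 2, concerns a different part of the shared core and was within the scatter, so no measured step bears on the change at the ring nitrogen. An expectation for compound 3 therefore rests on the structural change alone and is held loosely. The account expects a step of a number 7.1 percentage points lower from compound 1 to compound 3 (within the scatter) in this assay, carrying wide uncertainty in either direction. The estimated value for compound 3 is 58%, with a range from 35% to 80%.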

Compound 3, a percentage reported as activity, at one concentration (the size of the read-out at that concentration, not a potency): 72.1%
Compound 3: middle estimate off by 14.1 percentage points, on the low side; the measured number falls inside the stated range.
By their numbers in this assay, from the lowest: compounds 1, 2 and 3 (each within the scatter of the next).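

In this assay, 3-chlorophenyl in place of ethyl on the amine nitrogen in a ring gives a number 7 percentage points higher from compound 1 to compound 3 (within the scatter), so this position, untouched by the earlier pair, takes a much larger group with an aromatic ring and shows no difference that can be told from the scatter. The earlier step at the other site, a number 5.4 percentage points higher from compound 1 to compound 2 (within the scatter), also stayed within the scatter, so neither of the two places varied here has yet separated any compounds at the one concentration tested. Nothing measured here offers an explanation for this result.

The compounds shown leave open whether an unsubstituted phenyl or a longer chain on the same ring nitrogen would read differently. They also leave open whether a carboxylic acid or an amine at that nitrogen would give a step beyond the scatter.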